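Bromo to amino on a pentyl aminobenzimidazole core

A few compounds are considered here, and "the series" means these few. Any claim that something is new, unique, unknown or untested is made for them only; others in the source may bear on it.

Measured compounds:
compound 1 `CCCCCn1c(N)nc2ccccc21`, 3230 nM
compound 2 `CCCCCn1c(N)nc2c(Br)cccc21`, "not active" (no number reported)

In an assay on HEK293 cells for agonist activity at Toll-like receptor 8 (Homo sapiens), read by reporter gene assay (on this read-out lower numbers stand for an effect already at smaller amounts and higher numbers for an effect only at larger amounts of compound), compound 1 gives 3230 nM. Within the data shown here, compound 2 carries a bromo group on the shared core and in this assay compound 2 gives "not active" (no number reported), so no number stands for it and no step to compound 1 can be stated; the two results show only that compound 2 produced no measurable effect where compound 1 did. Compound 3 `CCCCCn1c(N)nc2c(N)cccc21` is the next compound. It differs from compound 2 as follows: amino in place of bromo on an aromatic carbon. Among the measured compounds shown here, no step between measured compounds covers this change, so the size and direction of the step in this assay cannot be taken from the data. The expectation for compound 3 in this assay is a value of 5000 nM, within a range from 800 nM to 30000 nM, with a real chance that again only a limit is reported.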

Compound 3, half-maximal effective concentration: 6600 nM
Estimate against measurement, compound 3: 1.3-fold (0.12 log units) below; the range from low to high includes it.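

In this assay this aromatic carbon proves able to carry a substituent with a number still reported: compound 2, with bromo there, gives "not active" (no number reported), while compound 3, with amino there, gives 6600 nM. No numerical step can be read between these two, but against the hydrogen of the shared core the amino group brings only a modest change, a 2.0-fold higher number from compound 1 to compound 3 (0.31 log units; beyond the scatter), so the loss of a measurable effect seen with bromo does not extend to every group at this position. Nothing at hand explains why the two groups differ.

Going by these compounds, whether a hydroxyl or a methoxy group on this carbon would behave like amino or like bromo remains open. So does whether fluoro, a smaller halogen, would also give no number.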